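The compounds below may be only part of what the source reports. "The series", "measured", "known", "first", "only" and "open" are said of these compounds alone.

Among the measured compounds shown here, in a functional assay on PC-3 cells (Homo sapiens) for inhibition, read by sulforhodamine B assay (on this read-out higher numbers stand for weaker inhibition of growth and lower numbers for stronger inhibition of growth), compound 2 `Oc1cccc2[nH]c(-c3ccc(-c4ccc(-c5ccc(OC(F)(F)F)cc5)cc4)cc3)nc12` gives 7410 nM, the highest of three numbers so far, while compound 3 `COc1ccc(-c2ccc(-c3ccc(-c4nc5c(O)cccc5[nH]4)cc3)cc2)cc1OC` gives 1240 nM. Compound 4 `Cc1ccc2[nH]c(-c3ccc(-c4ccc(-c5ccc(OC(F)(F)F)cc5)cc4)cc3)nc2c1` differs from compound 2 in one place: 5-methyl-1H-benzimidazol-2-yl in place of 4-hydroxy-1H-benzimidazol-2-yl on an aromatic carbon. For the measured compounds named here, no measured step covers this swap. Going by the values given here, the only step available, a 6.0-fold lower number from compound 2 to compound 3 (0.78 log units; beyond the scatter), changes a different group, so it shows only that one change can matter modestly here. Compound 1 `Cc1ccc2[nH]c(-c3ccc(-c4ccc(-c5cccc(Cl)c5)cc4)cc3)nc2c1` already carries the 5-methyl-1H-benzimidazol-2-yl group and gives 2670 nM, although it lacks the 4-(trifluoromethoxy)phenyl group. That value points to a lower number, and the expected step is small: a 2.1-fold lower number from compound 2 to compound 4 (0.33 log units; beyond the scatter). Compound 4 is estimated at 3500 nM, with an expected range from 1300 nM to 9000 nM.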

Compound 4, concentration for 50% growth inhibition: 2010 nM
Compound 4: middle estimate off by 1.7-fold (0.24 log units), on the high side; the measured number falls inside the stated range.
By their numbers in this assay, from the lowest: compounds 3, 4 and 1 (each within the scatter of the next, the first and the last beyond it); then compound 2.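

In this assay, among the compounds shown here, 5-methyl-1H-benzimidazol-2-yl in place of 4-hydroxy-1H-benzimidazol-2-yl gives a 3.7-fold lower number from compound 2 to compound 4 (0.57 log units; beyond the scatter), the first measured step for this swap, so this group does move the number. By contrast, 4-(trifluoromethoxy)phenyl in place of 3-chlorophenyl gives a 1.3-fold lower number from compound 1 to compound 4 (0.12 log units; within the scatter), a swap that shows no change that can be told from scatter. No measurement at hand explains either result. Still open, on these data alone, is whether the first step comes from losing the hydroxy group or from gaining the methyl group. As far as these compounds go, how an amine or a carboxylic acid would behave on this ring also stays unknown.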